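This account rests on a few compounds, and the source may have more. Where it says the series, first, only, none or still open, it means among the compounds named here.

Working notes on the chalcone series. Compound 1 `CN(C)Cc1cc(C(=O)/C=C/c2ccccc2Cl)cc(CN(C)C)c1O` gives 9550 nM in a functional assay on cells (Tumor Cell line, Homo sapiens) for cytotoxicity; a higher number here means a weaker inhibitor, a lower number a stronger inhibitor. Compound 2 `CN(C)Cc1cc(C(=O)/C=C/c2c(Cl)cccc2Cl)cc(CN(C)C)c1O` gives 5880 nM in this assay, and compound 3 `CN(C)Cc1cc(C(=O)/C=C/c2ccc([N+](=O)[O-])cc2)cc(CN(C)C)c1O` gives 8910 nM in this assay. Compound 2 is separated from compound 1 by a 1.6-fold lower number from compound 1 to compound 2 (0.21 log units; within the scatter) and from compound 3 by a 1.5-fold higher number from compound 2 to compound 3 (0.18 log units; within the scatter), so all three numbers sit within the scatter of one another and no ranking among them can be read.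

Compound 4 `CN(C)Cc1cc(C(=O)/C=C/c2ccc(O)cc2)cc(CN(C)C)c1O` differs from compound 2 in one place: 4-hydroxyphenyl in place of 2,6-dichlorophenyl on a double-bonded chain carbon bound to a double-bonded chain carbon. Going by the values given here, the steps that bear on this are the two earlier exchanges of the aryl group on the same chain carbon, a 1.1-fold lower number from compound 1 to compound 3 (0.03 log units; within the scatter) and a 1.5-fold higher number from compound 2 to compound 3 (0.18 log units; within the scatter), both within the scatter. Among the compounds with values here, no measured compound carries a hydroxyphenyl here, so the step to compound 4 is expected to stay within the scatter, in no set direction: a 1.3-fold higher number from compound 2 to compound 4 (0.11 log units; within the scatter). Compound 4 is therefore estimated at 7500 nM in this assay, with a range from 3000 nM to 19000 nM.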

Compound 4, half-maximal inhibitory concentration: 39800 nM
Compound 4: middle estimate off by 5.3-fold (0.72 log units), on the low side, and the stated range ends below it.
By their numbers in this assay, from the lowest: compounds 2, 3 and 1 (each within the scatter of the next); then compound 4.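

At this chain carbon the aryl group is not freely exchangeable in this assay: 4-hydroxyphenyl is the only group shown to leave the scatter, with (a 6.8-fold higher number from compound 2 to compound 4 (0.83 log units; beyond the scatter)) against 2,6-dichlorophenyl and (a 4.2-fold higher number from compound 1 to compound 4 (0.62 log units; beyond the scatter)) against 2-chlorophenyl. Hydroxy in place of nitro on the aromatic carbon gives the same result (a 4.5-fold higher number from compound 3 to compound 4 (0.65 log units; beyond the scatter)), so the three other aryl groups stay within the scatter of one another while compound 4 alone stands apart as the weaker inhibitor. No measurement among the data shown accounts for this step.

The compounds shown leave open whether the step belongs to hydroxy alone or would also come with a methoxy group, an amine or a carboxylic acid in its place on the phenyl ring. They also leave open whether it would hold on another core, since all four compounds share one.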